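The compounds below may be only part of what the source reports. "The series", "measured", "known", "first", "only" and "open" are said of these compounds alone.

The series rests on one shared core, carried by compound 1 `CN1C(=O)N(C)C2C1NC(=S)N2/N=C/C=C/c1ccccc1`, compound 2 `CCN1C(=O)N(CC)C2C1NC(=S)N2/N=C/C=C/c1ccccc1` and compound 3 `CCN1C(=O)N(CC)C2C1N=C(SC)N2/N=C/C=C/c1ccccc1`, all tested in a functional assay on MCF7 cells (Homo sapiens) for inhibition, read by MTT assay, with a stated time of 72 h; a lower number here means a stronger inhibitor, a higher number a weaker inhibitor. For compound 1 the result is only a limit of the assay, > 100000 nM, and not a number. Compound 2 gives 36100 nM in this assay. Compound 3 gives 46600 nM in this assay, a value that lies within the usual scatter of the number for compound 2, so the two cannot be told apart. For compound 1 there stands only (the limit of > 100000 nM in this assay, at which 1 of the 3 values shown sits). For the measured compounds named here, compound 3 is thus the one with a measured number that can be carried forward.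

The next compound, compound 4 `CCN1C(=O)N(CC)C2C1N=C(SC)N2/N=C/C=C/c1ccccc1OC`, differs from compound 3 in a single place: methoxy in place of hydrogen on an aromatic carbon. Going by the values given here, no measured pair in the set shows what such an addition does in this assay, so nothing beyond the structures themselves speaks for a direction. The expectation is therefore a small step, with no clear direction, and most likely one that does not pass beyond the scatter. That expectation means a step of a 1.2-fold lower number from compound 3 to compound 4 (0.09 log units; within the scatter). Compound 4 is accordingly estimated at 38000 nM in this assay, with a range from 13000 nM to 110000 nM.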

Compound 4, half-maximal inhibitory concentration: 34600 nM
Estimate against measurement, compound 4: 1.1-fold (0.04 log units) above; measured number inside the range.
By their numbers in this assay, from the lowest: compounds 4, 2 and 3 (each within the scatter of the next). At a limit, above all of these: compound 1.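

For the compounds shown here, compound 4 gives the first reading of any substitution on the aromatic ring, since compounds 1, 2 and 3 all carry an unsubstituted phenyl. In this assay, the change from phenyl to 2-methoxyphenyl, with methoxy ortho to a large group, produces a step that stays within the scatter (a 1.3-fold lower number from compound 3 to compound 4 (0.13 log units; within the scatter)), so compound 3 and compound 4 cannot be told apart, and this one position accepts methoxy without a measurable shift in either direction. Nothing measured here bears on why this step is so small, and the data offer no reason for it.

On these data alone, whether a different group on the same aromatic carbon, such as an amine, a carboxylic acid or a longer alkoxy chain, would carry the number beyond the scatter remains open, as does the effect of methoxy on other carbons of this ring. As far as these compounds go, the reading also rests on a single pair, so it remains open whether methoxy would give the same small step on compound 2, which has the thione form of the core in place of the methylthio group of compound 3.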